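Hydroxy in Place of Chloro on the Pyridyl Arm

The compounds below may be only part of what the source reports. "The series", "measured", "known", "first", "only" and "open" are said of these compounds alone.

Measured compounds:
compound 1 `CCCC(C)n1c(CC)nc2c(-c3ccc(O)nc3C(F)(F)F)ccnc21` gives 602 nM
compound 2 `CCCC(C)n1c(CC)nc2c(-c3ccc(OC)nc3C)ccnc21` gives 1.1 nM
compound 3 `CCCC(C)n1c(CC)nc2c(-c3ccc(Cl)nc3C)ccnc21` gives 6.6 nM

In an assay for binding affinity to Corticotropin releasing factor receptor (Rattus norvegicus) (on this read-out higher numbers stand for weaker inhibition and lower numbers for stronger inhibition), compound 3 holds the second highest of the three numbers; compound 2 sits nearest with a lower number, and compound 1 lies furthest, with a much higher one. The step from compound 3 to compound 4 `CCCC(C)n1c(CC)nc2c(-c3ccc(O)nc3C)ccnc21` is hydroxy in place of chloro on an aromatic carbon.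

Among the measured compounds shown here, only one measured step touches the same part of the molecule: a 6.0-fold higher number from compound 2 to compound 3 (0.78 log units; beyond the scatter), a modest shift beyond the scatter. Neither group in that step is hydroxy, so it shows only that this carbon is sensitive to what is attached. The single measured compound carrying a hydroxy group is compound 1, which also bears a trifluoromethyl instead of a methyl group; compound 1 gives 602 nM, by far the highest number shown, though no single step links it to compound 3 or compound 4.

On that basis compound 4 is expected to move toward weaker binding, with an estimated rise of an 18-fold higher number from compound 3 to compound 4 (1.26 log units; beyond the scatter). The estimate for compound 4 is 120 nM, within a range from 20 nM to 700 nM.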

Compound 4, inhibition constant: > 10000 nM
Compound 4: no number, only a limit; the forecaster's own chance of this, stated with the estimate: 5%; middle value at least 83-fold (1.92 log units) from the limit.
By their numbers in this assay, from the lowest: compound 2; then compound 3; then compound 1. At a limit, above all of these: compound 4.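

In this assay compound 4 stands at a limit of the assay and not at a number: the limit of > 10000 nM in this assay, at which 1 of the 4 values shown sits. Read as minimum sizes, the steps show that this carbon tolerates hydroxy far less well than the earlier exchange of methoxy for chloro could reveal: hydroxy in place of chloro gives an at least 1500-fold higher number from compound 3 to compound 4 (3.18 log units; beyond the scatter), and the loss of only the methyl on the oxygen gives an at least 9000-fold higher number from compound 2 to compound 4 (3.95 log units; beyond the scatter), so a single methyl separates the lowest number shown from the limit. Hydroxy at this carbon does not by itself settle the outcome, as methyl in place of trifluoromethyl on an aromatic carbon gives an at least 16-fold higher number from compound 1 to compound 4 (1.22 log units; beyond the scatter), which means that, of the two compounds carrying hydroxy, only compound 1 has a measured value.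

The compounds shown leave open whether an amine or a carboxylic acid on this carbon would behave like hydroxy, and whether ethoxy, with its longer chain on the oxygen, would stay close to compound 2 at 1.1 nM. They also leave open whether trifluoromethyl in place of methyl would change the numbers when methoxy or chloro occupies this carbon.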